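Side-chain swap on an inactive benzyl ether

A few compounds are considered here, and "the series" means these few. Any claim that something is new, unique, unknown or untested is made for them only; others in the source may bear on it.

- compound 1 `COc1cc(OC)c(-c2coc3cc(OCC(=O)c4cccc(C(F)(F)F)c4)ccc3c2=O)cc1OC` gives > 10000 nM
- compound 2 `COc1cc(OC)c(-c2coc3cc(OCc4ccc([N+](=O)[O-])cc4)ccc3c2=O)cc1OC` gives > 10000 nM
- compound 3 `COc1cc(OC)c(-c2coc3cc(OCc4ccccc4C(F)(F)F)ccc3c2=O)cc1OC` is not yet measured

In a functional assay on HCT-116 cells (Homo sapiens) for antiproliferative activity, read by MTT assay, with a stated time of 24 h (on this read-out lower numbers stand for stronger inhibition and higher numbers for weaker inhibition), compound 2 reads > 10000 nM, which is a limit and not a number. Compound 1 reads > 10000 nM, likewise a limit. The record so far is therefore (the limit of > 10000 nM in this assay, at which 2 of the 2 values shown sit).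

Compound 3 differs from compound 2 in one place: 2-(trifluoromethyl)phenyl in place of 4-nitrophenyl on a saturated chain carbon bound to an oxygen on an aromatic ring. In short, 4-nitrobenzyl gives way to 2-(trifluoromethyl)benzyl.

Within the data shown here, only one measured step bears on this change, a step that the two limits leave unreadable from compound 1 to compound 2. It has no readable size, so it supports no particular size or direction for the new step in this assay. Another weak result, possibly another limit, is expected. The expected step is a step that the limit leaves unreadable from compound 2 to compound 3, and it is only loosely defined. The estimate for compound 3 is 14000 nM, with a range of 4000 nM to 40000 nM.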

Compound 3, half-maximal inhibitory concentration: 4760 nM
For compound 3 the middle estimate is 2.9-fold (0.47 log units) above the measured one; the range from low to high includes it.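

In this assay, the change from 4-nitrobenzyl to 2-(trifluoromethyl)benzyl gives a step that can be read, an at least 2.1-fold lower number from compound 2 to compound 3 (0.32 log units; beyond the scatter), whereas the step between the two earlier compounds cannot be read. At the same place, 2-(trifluoromethyl)phenyl in place of (3-(trifluoromethyl)phenyl)carbonyl gives an at least 2.1-fold lower number from compound 1 to compound 3 (0.32 log units; beyond the scatter), so this position tolerates a change that moves the result in this assay off the limit. Compound 3 is the only one of the three compounds that gives a number rather than a limit: the limit of > 10000 nM in this assay, at which 2 of the 3 values shown sit.

From the compounds shown here alone, both steps give only a minimum size, so how far compound 1 and compound 2 truly lie from compound 3 remains open. Going by these compounds, it is also open how a plain benzyl group, or a benzyl group carrying an amine or a carboxylic acid, would read at this position.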